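Swapping Hydroxy for Amino on the Shared Core

The source may report more compounds than this note shows. Statements on the series, on what has been measured and on what is new or still open speak of the compounds shown alone.

Compound 1 `N#Cc1ccc(O[C@H]2CN(S(=O)(=O)c3ccc(Cl)cc3)C[C@@]2(O)CO)cc1F` gives 170 L/kg
Compound 2 `N#Cc1ccc(O[C@H]2CN(S(=O)(=O)c3ccc(C(F)(F)F)cc3)C[C@@]2(O)CO)cc1F` gives 180 L/kg
Compound 3 `N#Cc1ccc(O[C@H]2CN(S(=O)(=O)c3ccc(Cl)cn3)C[C@@]2(O)CO)cc1F` gives 12 L/kg

These three compounds were measured in an ADME assay on the whole organism (Rattus norvegicus, strain Sprague-Dawley) for pharmacokinetics, read by LC-MS, with a stated time of 30 min; on this read-out lower numbers stand for narrower distribution and higher numbers for wider distribution into tissues. Compound 3 stands lowest of the three numbers, and both steps that lead to it are large: a 14-fold lower number from compound 1 to compound 3 (1.15 log units; beyond the scatter) and a 15-fold lower number from compound 2 to compound 3 (1.18 log units; beyond the scatter). The remaining step, a 1.1-fold higher number from compound 1 to compound 2 (0.02 log units; within the scatter), lies within the scatter. All three steps change only the group carried on the sulfonyl sulfur.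

Compound 4 `N#Cc1ccc(O[C@H]2CN(S(=O)(=O)c3ccc(Cl)cn3)C[C@@]2(O)CN)cc1F` differs from compound 3 in a different part of the molecule: amino in place of hydroxy on a saturated chain carbon bound to a saturated ring carbon. Going by the values given here, no measured step alters this hydroxymethyl group, so none of the measured steps bears on the change. The numbers at hand therefore give no reason to expect a step beyond the scatter, but they also give no test of it, so the range must be wide. Compound 4 is expected to give 15 L/kg, with a range from 5 L/kg to 60 L/kg. This estimate means a step of a 1.3-fold higher number from compound 3 to compound 4 (0.10 log units; within the scatter).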

Compound 4, volume of distribution at steady state: 47 L/kg
Estimate against measurement, compound 4: 3.1-fold (0.50 log units) below, within the range that was stated.
By their numbers in this assay, from the lowest: compound 3; then compound 4; then compounds 1 and 2 (each within the scatter of the next).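

Going by these compounds alone, the earlier steps changed only the group on the sulfonyl sulfur, so this is the first reading at the hydroxymethyl group: in this assay, changing hydroxymethyl to aminomethyl gives a 3.9-fold higher number from compound 3 to compound 4 (0.59 log units; beyond the scatter). The step is modest but beyond the scatter, so this read-out does respond to a change at this position. It took only one heavy atom, oxygen for nitrogen, with the counted hydrogen-bond donors, acceptors and net charge unchanged, and nothing shown here gives a reason for the rise.

From the compounds shown here alone, it remains open whether amino in place of hydroxy would give a similar step on the 4-chlorophenyl or 4-(trifluoromethyl)phenyl compounds. Also open, going by these compounds, is how a methoxy group, a carboxylic acid or a longer chain ending in an amine would read at this place.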